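A few compounds are considered here, and "the series" means these few. Any claim that something is new, unique, unknown or untested is made for them only; others in the source may bear on it.

Compound 3 `NC(=O)[C@@H](CCC(F)(F)F)N(CC1CCOCC1)S(=O)(=O)c1ccc(Cl)cc1` is measured in an ADME assay on MDCKII-LE cells (Canis lupus familiaris) for permeability, read by transwell migration, in the apical to basolateral direction (a lower number here means that the compound crosses the layer more slowly, a higher number that the compound crosses the layer faster), where compound 3 gives 26.3 10^-6 cm/s. Compound 1 `NC(=O)[C@@H](CCC(F)(F)F)N(C[C@H]1CCCCO1)S(=O)(=O)c1ccc(Cl)cc1` gives 13.4 10^-6 cm/s and compound 2 `NC(=O)[C@@H](CCC(F)(F)F)N(C[C@@H]1CCCCO1)S(=O)(=O)c1ccc(Cl)cc1` gives 15.4 10^-6 cm/s; the steps of a 2.0-fold higher number from compound 1 to compound 3 (0.29 log units; within the scatter) and a 1.7-fold higher number from compound 2 to compound 3 (0.23 log units; within the scatter) stay within the scatter, and the step of a 1.1-fold higher number from compound 1 to compound 2 (0.06 log units; within the scatter) is explained by the fact that compounds 1 and 2 differ only in the configuration as drawn. Compound 4 `NC(=O)[C@@H](CCC(F)(F)F)N(C[C@H]1CCCO1)S(=O)(=O)c1ccc(Cl)cc1` differs from compound 3 by oxolan-2-yl in place of oxan-4-yl on a saturated chain carbon bound to a sulfonamide nitrogen. Among the compounds with values here, the steps that bear on this change, from compound 1 and from compound 2 to compound 3, moved the ring attachment without leaving the scatter, so for compound 4 only a step within the scatter is expected in this assay, in no firm direction. Compound 4 is thus estimated at 18 10^-6 cm/s, within 10 10^-6 cm/s to 32 10^-6 cm/s, a step of a 1.5-fold lower number from compound 3 to compound 4 (0.16 log units; within the scatter).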

Compound 4, apparent permeability: 19.1 10^-6 cm/s
Beside the measured number, compound 4's estimate is 1.1-fold (0.03 log units) below it, and the stated range covers the measured number.
By their numbers in this assay, from the lowest: compounds 1, 2, 4 and 3 (each within the scatter of the next).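

At this position, the five-membered oxolan-2-yl ring joins the six-membered rings, and this assay still does not separate them: the steps (a 1.4-fold lower number from compound 3 to compound 4 (0.14 log units; within the scatter)), (a 1.2-fold higher number from compound 2 to compound 4 (0.09 log units; within the scatter)) and (a 1.4-fold higher number from compound 1 to compound 4 (0.15 log units; within the scatter)) all stay within the scatter. Ring size thus adds a second change, after the place of ring attachment, that leaves the number within the scatter. Nothing known here gives a cause for these steps.

From the compounds shown here alone, whether an amine or a carboxylic acid in place of the ring would step beyond the scatter remains open. So does the number for the opposite configuration of the oxolan-2-yl ring.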